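Chloro to iodo on the phenyl ester of compound 3

This account rests on a few compounds, and the source may have more. Where it says the series, first, only, none or still open, it means among the compounds named here.

Measured compounds in a functional assay on HT-1080 cells (Homo sapiens), read by transwell migration, with a stated time of 24 h, tested at 1 uM; a lower number here means a stronger effect, a higher number a weaker effect of the compound at the concentration tested:
compound 1 `O=C(Oc1cccc(I)c1)c1cc2cc([N+](=O)[O-])ccc2oc1=O`: 63.6%
compound 2 `CC(=O)NCc1ccc2oc(=O)c(C(=O)Oc3ccccc3)cc2c1`: 63.5%
compound 3 `CC(=O)NCc1ccc2oc(=O)c(C(=O)Oc3cccc(Cl)c3)cc2c1`: 36.6%

Compound 3 stands lowest of the three numbers in this assay. Its nearest neighbour is compound 2, beyond the scatter, and compound 1 is further still, also beyond the scatter. For the measured compounds named here, the only single-place step measured is a number 26.9 percentage points lower from compound 2 to compound 3 (beyond the scatter), a modest step.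

Compound 4 `CC(=O)NCc1ccc2oc(=O)c(C(=O)Oc3cccc(I)c3)cc2c1` is the next member. It differs from compound 3 in one place: iodo in place of chloro on an aromatic carbon. Going by the values given here, no measured step covers a chloro-to-iodo exchange. Among the compounds with values here, compound 1 carries an iodo on its phenyl ester, but on a different core, and no step connects it to compound 3, so its value alone shows only that an iodophenyl ester can sit at the high end of this set. The halogen change from compound 3 is smaller in kind than the hydrogen-to-chloro step, so no step beyond the scatter is expected in this assay, with a slight lean to a somewhat higher number.

Compound 4 is therefore expected to give about 42% in this assay, likely between 22% and 62%, an expected step of a number 5.4 percentage points higher from compound 3 to compound 4 (within the scatter).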

Compound 4, a percentage reported as activity, at one concentration (the size of the read-out at that concentration, not a potency): 23.5%
Beside the measured number, compound 4's estimate is 18.5 percentage points above it, and the stated range covers the measured number.
By their numbers in this assay, from the lowest: compound 4; then compound 3; then compounds 2 and 1 (each within the scatter of the next).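

In this assay the change from 3-chlorophenyl to 3-iodophenyl gives a number 13.1 percentage points lower from compound 3 to compound 4 (beyond the scatter) and so shows that the identity of the halogen at this place matters, not only its presence. Iodo in place of hydrogen gives a number 40 percentage points lower from compound 2 to compound 4 (beyond the scatter) and completes an order across compounds 2, 3 and 4, with the number falling from hydrogen through chloro to iodo and none of the three going against it. With the 3-iodophenyl ester held constant, acetamidomethyl in place of nitro gives a number 40.1 percentage points lower from compound 1 to compound 4 (beyond the scatter) and shows that the iodo ester does not set the number alone.

On these data alone, whether bromo, fluoro or methoxy at the same place would fit this order remains open. The reason for these steps also remains open, as no supporting data bear on it.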